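The source may hold more compounds than are shown below. What is called first, only, known or untested is meant among the compounds shown, and "the series" means these compounds.

Compound 1 `O=C(Nc1cccc(C(F)(F)F)c1)c1ccc2cccc(O)c2n1` and compound 2 `O=C(Nc1ccc(C(F)(F)F)cc1)c1ccc2cccc(O)c2n1` are built from the same atoms joined differently, and the difference between the two cores is not broken down here. Compound 3 `O=C(Nc1cccc([N+](=O)[O-])c1)c1ccc2cccc(O)c2n1` arises from compound 1 by nitro in place of trifluoromethyl on an aromatic carbon on the ring that carries it. In an ADME assay on THP-1 cells (Homo sapiens) for cytotoxicity, read by WST assay, with a stated time of 24 h (on this read-out lower numbers stand for stronger inhibition and higher numbers for weaker inhibition), compound 1 gives only a limit of > 30000 nM rather than a number. Compound 2 likewise gives only a limit in this assay of > 30000 nM and no number. Compound 3 also stops at a limit in this assay of > 30000 nM with no number behind it. The step that the two limits leave unreadable from compound 1 to compound 3 therefore has no readable size, because the limit of > 30000 nM in this assay, at which 3 of the 3 values shown sit, leaves both ends open. Compound 4 `O=C(Nc1ccc([N+](=O)[O-])cc1)c1ccc2cccc(O)c2n1` differs from compound 2 by nitro in place of trifluoromethyl on an aromatic carbon and so carries the same kind of change as compound 3 carries relative to compound 1, though the place is not identical: in compound 3 the nitro sits meta to a large group, in compound 4 para to a large group. The step of a number no higher from compound 2 to compound 4 (the limit leaves the size open) is expected to be small, resting on a step that the two limits leave unreadable from compound 1 to compound 3 together with the limit of > 30000 nM in this assay, at which 3 of the 3 values shown sit, at which all three known values sit. Compound 4 is thus estimated at 30000 nM and is expected to return only a limit once more.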

Compound 4, half-maximal inhibitory concentration: > 30000 nM
Compound 4 gave a limit, no number (the forecaster's own chance of this, stated with the estimate: 85%); the middle value sits exactly at the limit.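

Compound 2 and compound 4 both stop at a limit rather than a number, and the step between them has no readable size. From the compounds shown here alone, whether nitro in place of trifluoromethyl changes anything in this assay stays open.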